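The source may report more compounds than this note shows. Statements on the series, on what has been measured and on what is new or still open speak of the compounds shown alone.

Measured so far:
- compound 1, `CCCCCCCCOC(=O)C(O)Cn1cnc2c(N)ncnc21`: in a functional assay on HeLa cells (Homo sapiens) for cytotoxicity (a higher number here means that more compound is tolerated, a lower number that less compound is tolerated), compound 1 gives 100 ug/mL
- compound 2, `COC(=O)C(O)Cn1cnc2c(N)ncnc21`: compound 2 gives > 400 ug/mL, which is a limit of the measurement rather than a number
- compound 3, `CCCCCOC(=O)C(O)Cn1cnc2c(N)ncnc21`: compound 3 gives > 400 ug/mL, again a limit rather than a number

Compound 3 therefore stands at the edge of what this assay can report, a point it shares with one further compound (the limit of > 400 ug/mL in this assay, at which 2 of the 3 values shown sit). Compound 4, `Nc1ncnc2c1ncn2CC(O)C(=O)OCc1ccco1`, has not yet been measured. It differs from compound 3 in one place: furan-2-yl in place of butyl on a saturated chain carbon bound to an oxygen next to a carbonyl group. For the measured compounds named here, two measured steps bear on this change. Both shortenings of the ester chain raised the tolerated amount beyond the scatter: an at least 4.0-fold higher number from compound 1 to compound 2 (0.60 log units; beyond the scatter) and an at least 4.0-fold higher number from compound 1 to compound 3 (0.60 log units; beyond the scatter). The step that the two limits leave unreadable from compound 2 to compound 3 gives no readable size. Compound 4 keeps a chain of (furan-2-yl)methyl rather than the long octyl chain of compound 1, so no step beyond the scatter is expected, a number no higher from compound 3 to compound 4 (the limit leaves the size open). Compound 4 is estimated at 400 ug/mL, within a range from 200 ug/mL to 800 ug/mL.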

Compound 4, minimum cytotoxic concentration: 40 ug/mL
Compound 4: the middle estimate sits 10-fold (1.00 log units) above what was measured; the measured number lies below the stated range.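

Until now, in this assay, only the octyl ester of compound 1 had pulled the tolerated amount down, which made a long chain look like the requirement at this place. The change from pentyl to (furan-2-yl)methyl breaks that reading, giving an at least 10-fold lower number from compound 3 to compound 4 (1.00 log units; beyond the scatter), while the comparison with the methyl ester gives an at least 10-fold lower number from compound 2 to compound 4 (1.00 log units; beyond the scatter). Compound 4 also falls past the octyl ester, with a 2.5-fold lower number from compound 1 to compound 4 (0.40 log units; beyond the scatter), so chain length alone does not order these esters, and compound 4 is the one that goes against it.

From the compounds shown here alone, the full size of the two larger steps stays open, as each starts from a limit rather than a number: the limit of > 400 ug/mL in this assay, at which 2 of the 4 values shown sit. Also open is whether the furan ring's oxygen matters or any aromatic ring would do, a question that a benzyl ester would address.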